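The source may hold more compounds than are shown below. What is called first, only, known or untested is meant among the compounds shown, and "the series" means these compounds.

Measured so far:
Compound 1 `CN1CCN(C2=Nc3ccccc3CC=C2c2ccc(F)cc2)CC1` — 79.3%
Compound 2 `CCN1CCN(C2=Nc3ccccc3CC=C2c2ccc(F)cc2)CC1` — 86.8%

In a functional assay on the whole organism with Mus musculus as the target, at a dose of 50 mg/kg by the oral route (on this read-out higher numbers stand for a stronger effect at the one dose given and lower numbers for a weaker effect), compound 2 gives 86.8%, and compound 1 gives 79.3%; the step of a number 7.5 percentage points higher from compound 1 to compound 2 (within the scatter) lies within the scatter, so the two numbers cannot be told apart. Compound 3 `CCCN1CCN(C2=Nc3ccccc3CC=C2c2ccc(F)cc2)CC1` differs from compound 2 by methyl in place of hydrogen on a saturated chain carbon, two bonds along the chain from an amine nitrogen in a ring. For the measured compounds named here, the one measured step that bears on this is a number 7.5 percentage points higher from compound 1 to compound 2 (within the scatter), a similar chain lengthening one bond nearer the ring nitrogen, and it stayed within the scatter. Compound 3 is therefore expected to show a step of a number 1.8 percentage points lower from compound 2 to compound 3 (within the scatter), no change beyond the scatter. Compound 3 is estimated at 85%, within a range from 70% to 95%.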

Compound 3, a percentage reported as inhibition, in the whole organism at one dose (the size of the read-out at that dose, not a potency): 61.4%
Compound 3: middle estimate off by 23.6 percentage points, on the high side; measured number below the stated range.
By their numbers in this assay, from the lowest: compound 3; then compounds 1 and 2 (each within the scatter of the next).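

In this assay, the chain on this ring nitrogen does not tolerate every added carbon: changing 4-ethylpiperazin-1-yl to 4-propylpiperazin-1-yl gives a number 25.4 percentage points lower from compound 2 to compound 3 (beyond the scatter), a change the methyl-to-ethyl step did not show. The propyl chain also falls short of methyl, with a number 17.9 percentage points lower from compound 1 to compound 3 (beyond the scatter), so the same one-carbon addition matters at this chain length. Nothing available explains this drop. Still open, from the compounds shown here alone, is whether a longer butyl chain lowers the number further, and whether a branched isopropyl group or a hydroxyl at the chain end behaves like propyl.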